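The compounds below may be only part of what the source reports. "The series", "measured", "known", "first", "only" and "open" are said of these compounds alone.

Cytotoxicity series, read in an ADME assay on HepG2 2.2.15 cells (Homo sapiens) for cytotoxicity; a higher number here means that more compound is tolerated, a lower number that less compound is tolerated:

Compound 1, `O=c1[nH]c2ccc(Cl)cc2c(-c2ccccc2Cl)c1CCO`: 380000 nM
Compound 2, `CCC(=O)OCCc1c(-c2ccccc2Cl)c2cc(Cl)ccc2[nH]c1=O`: 95000 nM
Compound 3, `O=C(OCCc1c(-c2ccccc2Cl)c2cc(Cl)ccc2[nH]c1=O)c1ccccc1`: 43000 nM

Compound 2 stands second highest of the three numbers; the nearest is compound 3, with a 2.2-fold lower number from compound 2 to compound 3 (0.34 log units; beyond the scatter), the furthest compound 1, with a 4.0-fold lower number from compound 1 to compound 2 (0.60 log units; beyond the scatter) in the reverse sense. Compound 4, `O=C(OCCc1c(-c2ccccc2Cl)c2cc(Cl)ccc2[nH]c1=O)c1cccnc1`, is still to be measured. It differs from compound 2 in one place: pyridin-3-yl in place of ethyl on a carbonyl carbon. The step that bears on this most directly is a 2.2-fold lower number from compound 2 to compound 3 (0.34 log units; beyond the scatter), where an aromatic six-membered ring likewise entered on the carbonyl carbon in place of ethyl; the other two steps, a 4.0-fold lower number from compound 1 to compound 2 (0.60 log units; beyond the scatter) and an 8.8-fold lower number from compound 1 to compound 3 (0.95 log units; beyond the scatter), show that each larger acyl group so far has lowered the number beyond the scatter. A six-membered aromatic ring with one hetero atom is expected to behave much like the phenyl of compound 3, so a modest lowering beyond the scatter is expected for compound 4, a 1.7-fold lower number from compound 2 to compound 4 (0.24 log units; within the scatter), and its value is estimated at 55000 nM, within 25000 nM to 130000 nM.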

Compound 4, half-maximal cytotoxic concentration: 170000 nM
The estimate for compound 4 lay 3.1-fold (0.49 log units) below the measured number; measured number outside the range, above it.
By their numbers in this assay, from the lowest: compound 3; then compounds 2 and 4 (each within the scatter of the next); then compound 1.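

In this assay, an aromatic six-membered ring on the carbonyl carbon does not by itself bring the lower number seen with phenyl: pyridin-3-yl in place of phenyl gives a 4.0-fold higher number from compound 3 to compound 4 (0.60 log units; beyond the scatter) and lies beyond the scatter. Pyridin-3-yl in place of ethyl gives a 1.8-fold higher number from compound 2 to compound 4 (0.25 log units; within the scatter) and stays within the scatter, so at this position the ring of compound 4 and the ethyl of compound 2 cannot be told apart. Compared with the free hydroxyl of compound 1, the ester of compound 4 still gives a 2.2-fold lower number from compound 1 to compound 4 (0.35 log units; beyond the scatter) and so keeps to the pattern of all three esters, but nothing measured here explains why the two rings differ.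

On these data alone, whether the placement of the ring nitrogen matters remains open, as pyridin-2-yl and pyridin-4-yl esters would test this. Also open, as far as these compounds go, is how a saturated ring such as piperidin-4-yl, or a longer chain such as hexanoyl on the oxygen, would read in this assay on the same core.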